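From bromo to benzyloxycarbonyl on the shared core

The compounds below may be only part of what the source reports. "The series", "measured", "known", "first", "only" and "open" are said of these compounds alone.

Measured in a functional assay on MCF7 cells (Homo sapiens) for antiproliferative activity, read by MTT assay, with a stated time of 48 h; a lower number here means a stronger inhibitor, a higher number a weaker inhibitor:
- compound 1 `O=C(OCc1ccccc1)c1ccc2[nH]c(-c3cn(-c4ccccc4)nc3-c3ccc(F)cc3)nc2c1` gives 9240 nM
- compound 2 `Fc1ccc2[nH]c(-c3cn(-c4ccccc4)nc3-c3ccc(Cl)cc3)nc2c1` gives 2830 nM
- compound 3 `Clc1ccc(-c2nn(-c3ccccc3)cc2-c2nc3cc(Br)ccc3[nH]2)cc1` gives 1920 nM

Compound 3 gives 1920 nM, which lies within the scatter of compound 2. Its number is clearly lower than that of compound 1, which gives 9240 nM. The next compound is compound 4 `O=C(OCc1ccccc1)c1ccc2[nH]c(-c3cn(-c4ccccc4)nc3-c3ccc(Cl)cc3)nc2c1`, which has not yet been measured. It departs from compound 3 by benzyloxycarbonyl in place of bromo on an aromatic carbon. Among the measured compounds shown here, no measured step covers this exchange directly. The nearest, a 1.5-fold lower number from compound 2 to compound 3 (0.17 log units; within the scatter), is bromo in place of fluoro and says little about so much larger a group. The better guide is compound 1 at 9240 nM, which also bears benzyloxycarbonyl, so a higher number is expected in this assay. The expected step, an estimate beyond the scatter, is a 3.1-fold higher number from compound 3 to compound 4 (0.49 log units; beyond the scatter). For compound 4 the estimated value is 6000 nM, with an expected range from 2500 nM to 14000 nM.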

Compound 4, half-maximal inhibitory concentration: 13900 nM
Compound 4: middle estimate off by 2.3-fold (0.36 log units), on the low side, within the range that was stated.
By their numbers in this assay, from the lowest: compounds 3 and 2 (each within the scatter of the next); then compounds 1 and 4 (each within the scatter of the next).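

In this assay, benzyloxycarbonyl on this aromatic carbon gives a 7.2-fold higher number from compound 3 to compound 4 (0.86 log units; beyond the scatter) against bromo and a 4.9-fold higher number from compound 2 to compound 4 (0.69 log units; beyond the scatter) against fluoro, so with the chloro group held fixed, both exchanges go beyond the scatter, whereas the exchange between the two halogens at this place did not. With benzyloxycarbonyl in place, the other exchange gives a 1.5-fold higher number from compound 1 to compound 4 (0.18 log units; within the scatter) and stays within the scatter, so chloro and fluoro are not told apart on this background. Nothing measured here explains why benzyloxycarbonyl gives the higher number.

The compounds shown leave open whether the change follows from the benzyl part or from the ester linkage, which a carboxylic acid, a methyl ester or a benzylamide on this carbon would help to separate. They also leave open how a plain hydrogen or an amine would read at this place.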